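The source may report more compounds than this note shows. Statements on the series, on what has been measured and on what is new or still open speak of the compounds shown alone.

The measured compounds:
Compound 1 `c1ccc2c(c1)CN[C@@H](CN(CCCCN(Cc1ccncc1)Cc1ccncc1)[C@H]1CCCc3cccnc31)C2`: 832 nM
Compound 2 `c1ccc2c(c1)CN[C@@H](CN(CCCCNC1CCCCC1)[C@H]1CCCc3cccnc31)C2`: 75.2 nM
Compound 3 `c1ccc2c(c1)CN[C@@H](CN(Cc1ccc(CNC3CCOCC3)cc1)[C@H]1CCCc3cccnc31)C2`: 90.3 nM

All three were tested in a functional assay on cells for antagonist activity at C-X-C chemokine receptor type 4 (Homo sapiens), read by fluorescence and calcium flux, with stated times of 25 min and 90 s; on this read-out higher numbers stand for weaker inhibition and lower numbers for stronger inhibition. Compound 3 stands second highest of the three numbers in this assay. Its nearest neighbour is compound 2, whose number lies within the usual scatter of that of compound 3, so the two cannot be told apart on these data. Compound 1 gives a higher number than compound 3, and that gap lies beyond the scatter.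

Compound 4 `c1ccc2c(c1)CN[C@@H](CN(Cc1ccc(CNCc3ccncc3)cc1)[C@H]1CCCc3cccnc31)C2` has not yet been measured in this assay. It differs from compound 3 by (pyridin-4-yl)methyl in place of oxan-4-yl on an amine nitrogen. Going by the values given here, no step between measured compounds isolates this change. Compound 1 carries two (pyridin-4-yl)methyl groups on an amine nitrogen and gives 832 nM, but compound 1 also differs from compound 4 elsewhere, so that comparison is only a loose pointer. The step is estimated as a 1.7-fold higher number from compound 3 to compound 4 (0.22 log units; within the scatter), small and toward a higher number, quite possibly within the scatter. Compound 4 is expected to give 150 nM, with a range from 50 nM to 500 nM.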

Compound 4, half-maximal inhibitory concentration in the C-X-C chemokine receptor type 4 assay: 134 nM
Compound 4: the middle estimate sits 1.1-fold (0.05 log units) above what was measured, and the stated range covers the measured number.
By their numbers in the C-X-C chemokine receptor type 4 assay, from the lowest: compounds 2, 3 and 4 (each within the scatter of the next); then compound 1.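

In the C-X-C chemokine receptor type 4 assay compound 3 gives 90.3 nM and compound 4 gives 134 nM. In the C-X-C chemokine receptor type 4 assay (pyridin-4-yl)methyl in place of oxan-4-yl on an amine nitrogen gives a 1.5-fold higher number from compound 3 to compound 4 (0.17 log units; within the scatter) and this is the first step among these compounds that isolates a change in one place. It shows that, with the rest of the structure held fixed, a six-membered non-aromatic ring carrying one oxygen and a methylene-linked six-membered aromatic ring carrying one nitrogen cannot be told apart on this read-out, so this amine nitrogen accepts either group without a change that the data can resolve. Nothing available here bears on why the two groups read alike.

On these data alone, whether a plain benzyl group, a (pyridin-2-yl)methyl group or an acetyl group on this same nitrogen would read the same remains open, as does whether the step would hold on the chain of compound 2 rather than on the benzene-containing linker of compound 3. As far as these compounds go, in a physicochemical assay for permeability, using PAMPA, with a stated time of 4 h, at pH 5.5, tested at 100 uM (on this read-out higher numbers stand for higher permeability and lower numbers for lower permeability), compound 3 is recorded as "not determined" (no result reported) and compound 4 is recorded as "not determined" (no result reported) so no step can be read there and the effect of this change on apparent permeability stays unknown.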